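The source may report more compounds than this note shows. Statements on the series, on what has been measured and on what is new or still open speak of the compounds shown alone.

Working notes on the series in an ADME assay for pharmacokinetics, read by LC-MS, in phosphate buffer, with a stated time of 120 min, at pH 7.4, tested at 1 uM, in the presence of a further agent that is not named here; a lower number here means that the compound disappears faster, a higher number that the compound lasts longer.

Three anilides have been measured. Compound 1 `O=C(/C=C/CN1CCCCC1)Nc1ccccc1` gives 2.95 h. Compound 3 `O=C(/C=C/C(F)(F)F)Nc1ccccc1` gives 0.267 h and stands lowest of the two numbers in hand; the gap from compound 3 up to compound 1 lies well beyond the usual scatter. Compound 2 `O=C(/C=C/CC(=O)Nc1ccccc1)Nc1ccccc1` reaches only the limit of the assay, reported as > 8.53 h, which is a limit and not a number; see (the limit of > 8.53 h in this assay, at which 1 of the 3 values shown sits).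

Compound 4 `CN(C)CC/C=C/C(=O)Nc1ccccc1` has not yet been measured. It differs from compound 3 by 2-(dimethylamino)ethyl in place of trifluoromethyl on a double-bonded chain carbon bound to a double-bonded chain carbon. The group that enters brings a hydrogen-bond acceptor where compound 3 has none, and in that respect compound 4 comes closer to compound 1 than compound 3 does.

A step upward in this assay is therefore expected from compound 3 to compound 4, because compound 1 gives 2.95 h while compound 3 gives 0.267 h. The expected value for compound 4 is 2.5 h, with a range from 0.8 h to 8 h. This expectation means a step of a 9.4-fold higher number from compound 3 to compound 4 (0.97 log units; beyond the scatter), beyond the scatter in direction of a longer half-life, though the range admits a smaller change.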

Compound 4, half-life: 7.38 h
For compound 4 the middle estimate is 3.0-fold (0.47 log units) below the measured one; the measured number falls inside the stated range.
By their numbers in this assay, from the lowest: compound 3; then compound 1; then compound 4. At a limit, above all of these: compound 2.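

In this assay, the place on a double-bonded chain carbon bound to a double-bonded chain carbon proves highly sensitive to the group it carries: 2-(dimethylamino)ethyl in place of trifluoromethyl gives a 28-fold higher number from compound 3 to compound 4 (1.44 log units; beyond the scatter). The amine-bearing chains also differ from one another, though by much less: (dimethylamino)methyl in place of piperidin-1-yl on a saturated chain carbon bound to a double-bonded chain carbon gives a 2.5-fold higher number from compound 1 to compound 4 (0.40 log units; beyond the scatter). Compound 1 and compound 4, which both carry an amine in the chain, stand above compound 3, but compound 2 carries no such amine and goes against any reading that ties a long half-life to the amine alone.

Compound 2 stands at a limit and not at a number, which leaves the size of its separation from the other compounds undefined: the limit of > 8.53 h in this assay, at which 1 of the 4 values shown sits. The compounds shown do not tell how a carboxylic acid or a longer chain ending in an amine would read at this place, nor what lies behind either step.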